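This account rests on a few compounds, and the source may have more. Where it says the series, first, only, none or still open, it means among the compounds named here.

Notes on the series around compound 3 and its ester analogue.

The three measured compounds share one core and differ only in the group on the carbonyl carbon. In an assay on HL-60 cells for agonist activity at vitamin D3 receptor (Homo sapiens), read by microscopy, with a stated time of 96 h (a higher number here means that more compound is needed for the effect, a lower number that less compound is needed), compound 1 `CCn1c(C(=O)NCCN(C)C)ccc1C(CC)(CC)c1ccc(OCC(O)C(C)(C)C)c(C)c1` gives 14 nM. Compound 2 `CCn1c(C(=O)NCCCN(C)C)ccc1C(CC)(CC)c1ccc(OCC(O)C(C)(C)C)c(C)c1` gives 37 nM in this assay, and compound 3 `CCn1c(C(=O)NCC(OC)OC)ccc1C(CC)(CC)c1ccc(OCC(O)C(C)(C)C)c(C)c1` gives 150 nM. Compound 3 therefore stands highest of the three numbers: an 11-fold higher number from compound 1 to compound 3 (1.03 log units; beyond the scatter) and a 4.1-fold higher number from compound 2 to compound 3 (0.61 log units; beyond the scatter), while between the two amine-bearing amides the step is smaller, a 2.6-fold higher number from compound 1 to compound 2 (0.42 log units; beyond the scatter).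

Compound 4 `C#CC(C)OC(=O)c1ccc(C(CC)(CC)c2ccc(OCC(O)C(C)(C)C)c(C)c2)n1CC` is not yet measured in this assay. It differs from compound 3 as follows: (1-methylprop-2-yn-1-yl)oxy in place of (2,2-dimethoxyethyl)amino on a carbonyl carbon. Going by the values given here, no measured step exchanges the amide for an ester; all three steps swap one amide substituent for another, and the one that removed the basic chain was the largest of them. The step from compound 3 to compound 4 is thus outside the measured set, and its direction cannot be taken from the data. A step of modest size in either direction is considered possible, with the uncertainty wide. Compound 4 is estimated at 200 nM, with a range of 50 nM to 800 nM, which means an expected step of a 1.3-fold higher number from compound 3 to compound 4 (0.12 log units; within the scatter).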

Compound 4, half-maximal effective concentration: 200 nM
Beside the measured number, compound 4's estimate shows no gap at the digits printed; the measured number falls inside the stated range.
By their numbers in this assay, from the lowest: compound 1; then compound 2; then compounds 3 and 4 (each within the scatter of the next).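

In this assay, the exchange of an amide for an ester on this carbonyl carbon can now be read, and a 1.3-fold higher number from compound 3 to compound 4 (0.12 log units; within the scatter) puts (1-methylprop-2-yn-1-yl)oxy level with (2,2-dimethoxyethyl)amino. The amide hydrogen is absent from compound 4, and this pair still gives no separable difference, so an amide-type nitrogen on the carbonyl carbon is not required for a number in this range. Against the amine-bearing amides the gaps are wider, with a 5.4-fold higher number from compound 2 to compound 4 (0.73 log units; beyond the scatter) and a 14-fold higher number from compound 1 to compound 4 (1.15 log units; beyond the scatter) the latter being the largest step to the new compound, so across all four compounds the two with a dimethylamino group give the lower numbers and compounds 3 and 4 stay together at the high end.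

Open, going by these compounds, is whether a 2-(dimethylamino)ethyl ester would reach the numbers of the amine-bearing amides, which would separate the dimethylamino group from the amide link. Also open, on these data alone, is what the triple bond contributes, which a saturated butan-2-yl ester would test, and how a free carboxylic acid on this carbonyl carbon would compare. Nothing measured here accounts for any of these steps.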